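The source may report more compounds than this note shows. Statements on the series, on what has been measured and on what is new or still open speak of the compounds shown alone.

Three compounds share one core and differ only in the group carried on one aromatic carbon. In a functional assay on HeLa cells (Homo sapiens) for cytotoxicity, with a stated time of 72 h (on this read-out higher numbers stand for weaker inhibition and lower numbers for stronger inhibition), compound 1, `Fc1ccc(-c2nc3sc(Cc4ccc(Cl)cc4)nn3c2Br)cc1`, gives > 250000 nM, which is a limit of the assay rather than a number. Compound 2, `COc1ccc(-c2nc3sc(Cc4ccc(Cl)cc4)nn3c2Br)cc1`, gives 66000 nM in this assay. Compound 3, `Cc1ccc(-c2nc3sc(Cc4ccc(Cl)cc4)nn3c2Br)cc1`, gives > 250000 nM, again a limit. Thus an at least 3.7-fold lower number from compound 1 to compound 2 (0.57 log units; beyond the scatter) and an at least 3.7-fold higher number from compound 2 to compound 3 (0.57 log units; beyond the scatter), while a step that the two limits leave unreadable from compound 1 to compound 3. Compound 3 therefore sits at the limit of > 250000 nM in this assay, at which 2 of the 3 values shown sit, and only compound 2 yields a real number.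

Compound 4, `Cc1ccc(-c2nc3sc(Cc4ccc(Cl)cc4)nn3c2C=O)cc1`, differs from compound 3 in that (formyl in place of bromo on an aromatic carbon). None of the three measured steps touches this place: each swaps fluoro, methoxy or methyl on the other aromatic carbon, so no step bears on the exchange of bromo for formyl, and neither the direction nor the size of the change is readable from the numbers shown. Compound 4 is expected to stay near the same limit, estimated at 180000 nM with a range from 40000 nM to 600000 nM. This expectation means a step of an at least 1.3-fold lower number from compound 3 to compound 4 (0.14 log units; that floor lies within the scatter).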

Compound 4, half-maximal inhibitory concentration: 21000 nM
Beside the measured number, compound 4's estimate is 8.6-fold (0.93 log units) above it, and the stated range ends above it.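

Among these compounds, the earlier steps all changed the group on the other aromatic carbon, so this is the first look at the place that carries bromo, and that place proves able to move the read-out: in this assay, formyl in place of bromo gives an at least 11-fold lower number from compound 3 to compound 4 (1.07 log units; beyond the scatter). The true size of this step may be larger, since compound 3 starts from a limit and not a number: the limit of > 250000 nM in this assay, at which 2 of the 4 values shown sit. The result shows that a methyl-bearing compound stuck at that limit can yield a real number through a change at this one place.

The compounds shown leave open whether formyl has a similar effect with fluoro or methoxy in place of that methyl. They also leave open how a carboxylic acid, an amine or a longer chain at this place would read, so what in the formyl group matters cannot be told.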